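This account rests on a few compounds, and the source may have more. Where it says the series, first, only, none or still open, it means among the compounds named here.

Series notes. In a functional assay on A549 cells (Homo sapiens) for inhibition, with a stated time of 72 h (on this read-out higher numbers stand for weaker inhibition and lower numbers for stronger inhibition), compound 1 `COc1ccc(C2Cc3ccccc3C(C3=C(O)OC(C)(c4ccccc4)CC3=O)C2)cc1` reaches only the limit of the assay, at > 10000 nM. Among the compounds with values here, compound 2 `CCC1(c2ccccc2)CC(=O)C(C2CC(c3ccc(OCc4ccc(C(F)(F)F)cc4)cc3)Cc3ccccc32)=C(O)O1` likewise gives in this assay only a limit, > 10000 nM, so compound 2 stands at the edge of what the assay can report, not at a number; the same holds across the series so far, since (the limit of > 10000 nM in this assay, at which 2 of the 2 values shown sit).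

Compound 3 `CCC1(c2ccccc2)CC(=O)C(C2CC(c3ccc(OC)cc3)Cc3ccccc32)=C(O)O1` is the next member for this assay. It differs from compound 2 by hydrogen in place of 4-(trifluoromethyl)phenyl on a saturated chain carbon bound to an oxygen on an aromatic ring. Compound 3 also carries the same methoxy on the aromatic ring as compound 1, whose value in this assay is a limit.

Within the data shown here, no measured step between compounds exists here, so no size of change is established. With both measured compounds at the limit, the expectation for compound 3 in this assay is a step that the limit leaves unreadable from compound 2 to compound 3, that is, none beyond the scatter, and most likely again a limit rather than a number. Compound 3 is estimated at 15000 nM, in the range 5000 nM to 50000 nM.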

Compound 3, half-maximal inhibitory concentration: > 10000 nM
Compound 3 was reported as a limit; the forecaster's own chance of this, stated with the estimate: 80%; the middle value lies beyond the limit too.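

In this assay compound 3 gives > 10000 nM as a limit of the assay, not a number. With compound 1 and compound 2 also at the limit, neither step to compound 3 can be read. The compounds shown leave open whether exchanging (4-(trifluoromethyl)benzyl)oxy for methoxy changes inhibition at all, and what any measurable value in this series would be.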